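The compounds below may be only part of what the source reports. "The series", "measured", "known", "first", "only" and "open" are said of these compounds alone.

Compound 2 `COc1ccc(S(=O)(=O)c2cnc3c(F)cccc3c2-c2cccc(Cl)c2)cc1` carries a 4-methoxyphenyl group on its sulfonyl sulfur. Among the measured compounds shown here, in an ADME assay on microsomes from liver (Homo sapiens) for metabolic stability, tested at 2.5 uM (on this read-out lower numbers stand for slow clearance and higher numbers for fast clearance), compound 2 gives 2.75 mL/min, the highest of the two numbers measured so far. For the measured compounds named here, the only comparison is compound 1 `O=S(=O)(c1cc(F)cc(F)c1)c1cnc2c(F)cccc2c1-c1cccc(Cl)c1`, which bears a 3,5-difluorophenyl group at the same place and in this assay gives 0.64 mL/min; the step of a 4.3-fold higher number from compound 1 to compound 2 (0.63 log units; beyond the scatter) shows that moving to the methoxy-bearing ring raised the clearance. Compound 3 `N#Cc1cccc(S(=O)(=O)c2cnc3c(F)cccc3c2-c2cccc(Cl)c2)c1` has not yet been measured. It differs from compound 2 in one place: 3-cyanophenyl in place of 4-methoxyphenyl on a sulfonyl sulfur. The methoxy-bearing ring that went with the higher number of compound 2 is gone again, so a downward step is expected for compound 3 because of the step of a 4.3-fold higher number from compound 1 to compound 2 (0.63 log units; beyond the scatter), although a single step is a thin basis. The expected change is a 2.8-fold lower number from compound 2 to compound 3 (0.44 log units; beyond the scatter). Compound 3 is therefore estimated at 1 mL/min, with a likely range from 0.4 mL/min to 2.6 mL/min.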

Compound 3, intrinsic clearance in a liver preparation (reported as CLH), per the amount of preparation that the assay uses: 1.11 mL/min
Compound 3: middle estimate off by 1.1-fold (0.05 log units), on the low side, within the range that was stated.
By their numbers in this assay, from the lowest: compounds 1 and 3 (each within the scatter of the next); then compound 2.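

In this assay the swap of 4-methoxyphenyl for 3-cyanophenyl gives a 2.5-fold lower number from compound 2 to compound 3 (0.39 log units; beyond the scatter) and so adds a second replacement of the 4-methoxyphenyl ring that goes with a number beyond the scatter. The step of a 1.7-fold higher number from compound 1 to compound 3 (0.24 log units; within the scatter) means that 3-cyanophenyl and 3,5-difluorophenyl cannot be told apart on this read-out, even though their substituents differ. Among these three compounds, then, only compound 2 stands apart, and no measured evidence here accounts for that. From the compounds shown here alone, all three compounds carry an aromatic ring on the sulfonyl sulfur, so it remains open how a chain ending in an amine or a carboxylic acid would behave at this place.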